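This account rests on a few compounds, and the source may have more. Where it says the series, first, only, none or still open, it means among the compounds named here.

In a functional assay on MDA-MB-231 cells (Homo sapiens) for inhibition, read by MTT assay, with a stated time of 72 h (on this read-out lower numbers stand for stronger inhibition and higher numbers for weaker inhibition), two compounds have been measured so far:

- compound 1 `COc1ccccc1-c1csc2cnc(Nc3ccc(NC(=O)[C@H]4CCCNC4)cc3)nc12` gives 440 nM
- compound 2 `COc1ccccc1-c1csc2cnc(Nc3ccc(C(=O)NC4CCNCC4)c(C)c3)nc12` gives 240 nM

The two numbers lie within the usual scatter of repeated measurements, so they set no order, and compound 1 stands level with compound 2 on this evidence. The next compound to be measured is compound 3 `COc1ccccc1-c1csc2cnc(Nc3ccc(NC(=O)CN)cc3)nc12`, which keeps the core of compound 1 and alters one group. aminomethyl in place of piperidin-3-yl on a carbonyl carbon is the whole change, aminomethyl in place of piperidin-3-yl on a carbonyl carbon. Among the measured compounds shown here, no measured pair yet shows what such a change does in this assay, so any expectation here must stay broad. With compound 1 at 440 nM as the only starting point, a modest step towards a higher number, meaning weaker inhibition, is expected, though a result within the scatter would not surprise. The expected size is a 1.8-fold higher number from compound 1 to compound 3 (0.26 log units; within the scatter) and the data support no sharper figure. For compound 3 the estimated value is 800 nM, with an expected range of 250 nM to 2500 nM and the measurement still to come.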

Compound 3, half-maximal inhibitory concentration: 2770 nM
The estimate for compound 3 lay 3.5-fold (0.54 log units) below the measured number; measured number above the stated range.
By their numbers in this assay, from the lowest: compounds 2 and 1 (each within the scatter of the next); then compound 3.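

In this assay, among the compounds shown here, the group on the carbonyl carbon whose other neighbour is the amide-type nitrogen proves able to shift the read-out: aminomethyl in place of piperidin-3-yl gives a 6.3-fold higher number from compound 1 to compound 3 (0.80 log units; beyond the scatter) and thus weaker inhibition, the first change to lie beyond the scatter. The change removes the six-membered non-aromatic ring and the defined stereocentre and leaves the hydrogen-bond donor and acceptor counts as they were, so this position responds to a change that keeps those counts, although this single pair cannot show which part of the change carries the loss. Nothing measured beyond the read-out itself bears on why the number rose, so the step stands without an explanation.

The compounds shown leave open whether the ring itself, the stereocentre or simply the length of the group matters, and a longer chain such as aminoethyl, a smaller ring such as pyrrolidin-3-yl or the opposite stereoisomer of piperidin-3-yl would help separate these. They also leave open whether the ring nitrogen is needed, which a plain cyclohexyl group in the same place would address.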